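Moving the methoxy group: compound 2 to compound 4

The compounds below may be only part of what the source reports. "The series", "measured", "known", "first", "only" and "open" are said of these compounds alone.

Measured so far:
- compound 1 (`COc1cc(/C=C/C(=O)/C=C/c2cccc3ccccc23)ccc1OCc1cn(CCCOc2cc(=O)oc3ccccc23)nn1`) gives 66%
- compound 2 (`COc1cccc(/C=C/C(=O)/C=C/c2ccc(OCc3cn(CCCCCOc4cc(=O)oc5ccccc45)nn3)c(OC)c2)c1`) gives 36%
- compound 3 (`COc1cccc(/C=C/C(=O)/C=C/c2ccc(OCc3cn(CCCCOc4cc(=O)oc5ccccc45)nn3)c(OC)c2)c1`) gives 44%

All three values come from a functional assay on HCT-116 cells (Homo sapiens) for inhibition, read by sulforhodamine B assay, with a stated time of 48 h, tested at 50 uM (on this read-out lower numbers stand for less inhibition of growth and higher numbers for more inhibition of growth at the one concentration tested), and span a modest part of that scale. Compound 2 (36%) cannot be separated from compound 3 (44%), as the two lie within the scatter of each other. Compound 1 (66%) stands higher than compound 2, and that gap is beyond the scatter.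

The next compound is compound 4 (`COc1ccc(/C=C/C(=O)/C=C/c2ccc(OCc3cn(CCCCCOc4cc(=O)oc5ccccc45)nn3)c(OC)c2)cc1`). Its difference from compound 2 is 4-methoxyphenyl in place of 3-methoxyphenyl on a double-bonded chain carbon bound to a double-bonded chain carbon. Everything else in compound 2 is kept.

Going by the values given here, no measured pair isolates this change, so the data give no direct guide to its size or direction. The expectation therefore starts from compound 2 (36%) and allows a wide range. The estimated step (a number 2 percentage points higher from compound 2 to compound 4 (within the scatter)) is expected to stay within the scatter in this assay, with no firm direction. The estimate for compound 4 is 38% (expected range 22% to 55%).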

Compound 4, percent growth inhibition at one concentration: 35%
Compound 4: the middle estimate sits 3 percentage points above what was measured, and the stated range covers the measured number.
By their numbers in this assay, from the lowest: compounds 4, 2 and 3 (each within the scatter of the next); then compound 1.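

In this assay, 4-methoxyphenyl in place of 3-methoxyphenyl on a double-bonded chain carbon bound to a double-bonded chain carbon gives a number 1 percentage points lower from compound 2 to compound 4 (within the scatter), and this is the first pair shown that isolates one change. With everything else in compound 2 kept, the two methoxyphenyl groups cannot be told apart by this read-out at the one concentration tested, so this exchange at this place does not separate the compounds. No measurement shown speaks to the reason for this outcome.

Still open, going by these compounds, is whether a different group at the same place, such as 2-methoxyphenyl, a dimethylaminophenyl group or a carboxylic acid on the phenyl ring, would give a step beyond the scatter. Also open, on these data alone, is whether the same exchange would give a comparable result with the rest of compound 3 kept, and what part of the structure accounts for compound 1 at 66%, since compound 1 differs from the others in more than one place.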